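Piperazine demethylation in the thiazolone series

The source may report more compounds than this note shows. Statements on the series, on what has been measured and on what is new or still open speak of the compounds shown alone.

Measured so far in a functional assay on H460/TaxR cells (Homo sapiens) for cytotoxicity, read by sulforhodamine B assay, with a stated time of 48 h; on this read-out lower numbers stand for an effect already at smaller amounts and higher numbers for an effect only at larger amounts of compound:
compound 1 `CCN(CC)c1ccc(/C=C2/SC(N(C)c3ccccc3)=NC2=O)cc1` gives 430 nM.
Compound 2 `CN1CCN(c2ccc(/C=C3/SC(N(C)c4ccccc4)=NC3=O)cc2)CC1` gives only a limit, > 100000 nM, not a number.

Compound 2 thus sits at the limit of > 100000 nM in this assay, at which 1 of the 2 values shown sits, where the read-out stops. Going by the values given here, the only measured step, an at least 230-fold higher number from compound 1 to compound 2 (2.36 log units; beyond the scatter), is the exchange of diethylamino for 4-methylpiperazin-1-yl on an aromatic carbon.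

Compound 3 `CN(C1=NC(=O)/C(=C\c2ccc(N3CCNCC3)cc2)S1)c1ccccc1` differs from compound 2 by hydrogen in place of methyl on an amine nitrogen in a ring. Among the compounds with values here, no measured step touches this amine nitrogen; the step from compound 1 to compound 2 concerns another place and only shows that the piperazine-bearing compound 2 gives no number. For compound 3 no step beyond the scatter is expected, a number no higher from compound 2 to compound 3 (the limit leaves the size open), since the starting point is already a limit. Compound 3 is therefore estimated at 100000 nM, with a range from 20000 nM to 300000 nM, most likely again reported as a limit.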

Compound 3, half-maximal effective concentration: > 100000 nM
Compound 3 gave a limit, no number; the forecaster's own chance of this, stated with the estimate: 70%; the middle value lies on the limit itself.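

In this assay compound 3 gives > 100000 nM, which is a limit and not a number. Hydrogen in place of methyl on the ring amine nitrogen brings no number back, and the step between the two limits cannot be read; with or without this methyl, the piperazine-bearing compounds end up at the same limit: the limit of > 100000 nM in this assay, at which 2 of the 3 values shown sit. The exchange on the aromatic carbon now also stands for piperazin-1-yl, with an at least 230-fold higher number from compound 1 to compound 3 (2.36 log units; beyond the scatter).

On these data alone, how far compound 2 and compound 3 actually lie apart stays open. Also open, as far as these compounds go, is whether the number is lost only with a piperazine ring, or also with morpholin-4-yl, piperidin-1-yl or dimethylamino in place of diethylamino on the same aromatic carbon.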